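Moving a Halogen on Compounds That Reach Only the Assay Limit

This account rests on a few compounds, and the source may have more. Where it says the series, first, only, none or still open, it means among the compounds named here.

Three related compounds have so far been tested in a functional assay on K562 cells (Homo sapiens) for antiproliferative activity, read by MTT assay, with a stated time of 24 h; a lower number here means a stronger inhibitor, a higher number a weaker inhibitor. Compound 1 `COc1cc(OC)c(OC)cc1/C=C/C(=O)c1ccc(OC)c2c1OC(C)(C)C=C2` gives a result that is only a limit of the assay, > 10000 nM. Compound 2 `COc1ccc(C(=O)/C=C/c2ccc(F)cc2)c2c1C=CC(C)(C)O2` likewise reaches only the limit, > 10000 nM. Compound 3 `COc1ccc(C(=O)/C=C/c2ccc(N(c3ccccc3)c3ccccc3)cc2)c2c1C=CC(C)(C)O2` also stops at the limit, > 10000 nM. Going by the values given here, compound 2 thus stands exactly where its two companions stand: every value seen so far is the limit (the limit of > 10000 nM in this assay, at which 3 of the 3 values shown sit), and no step between measured compounds can be drawn from these numbers.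

Compound 4 `COc1ccc(C(=O)/C=C/c2cccc(Cl)c2)c2c1C=CC(C)(C)O2` differs from compound 2 in one place: 3-chlorophenyl in place of 4-fluorophenyl on a double-bonded chain carbon bound to a double-bonded chain carbon. Among the compounds with values here, with no measured step to lean on, a change of this kind gives no ground to expect a move beyond the usual scatter in this assay in either direction. The expected step is a number no higher from compound 2 to compound 4 (the limit leaves the size open), essentially none. Compound 4 is therefore estimated at 10000 nM in this assay, with a likely range from 5000 nM to 40000 nM, and most probably the assay will again report only a limit.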

Compound 4, half-maximal inhibitory concentration: > 10000 nM
Compound 4: no number, only a limit (the forecaster's own chance of this, stated with the estimate: 85%); the middle value sits exactly at the limit.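

In this assay compound 4 gives only a limit, > 10000 nM, so the step from compound 2 to compound 4 cannot be read. The compounds shown leave open whether 3-chlorophenyl and 4-fluorophenyl differ at all, and which change would give a true number: the limit of > 10000 nM in this assay, at which 4 of the 4 values shown sit.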